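A few compounds are considered here, and "the series" means these few. Any claim that something is new, unique, unknown or untested is made for them only; others in the source may bear on it.

Measured compounds:
- compound 1, `CCCn1c(=O)[nH]c2nc(-c3ccc(S(=O)(=O)N4CCN(c5ccc(F)cc5)CC4)cc3)[nH]c2c1=O`: 38%
- compound 2, `CCCn1c(=O)[nH]c2nc(-c3ccc(S(=O)(=O)N4CCN(c5ccc(Cl)cc5F)CC4)cc3)[nH]c2c1=O`: 14%
- compound 3, `CCCn1c(=O)[nH]c2nc(-c3ccc(S(=O)(=O)N4CCN(Cc5cccc(C)c5)CC4)cc3)[nH]c2c1=O`: 17%

In an assay on CHO cells for displacement of a labelled ligand from adenosine receptor A3 (Homo sapiens), read by scintillation counting, with a stated time of 45 min, tested at 1 uM, in the presence of a further agent that is not named here (on this read-out lower numbers stand for less inhibition and higher numbers for more inhibition at the one concentration tested (going by the name of the read-out)), compound 1 gives the highest of the three numbers. Its two neighbours both fall clearly beneath it: the step of a number 24 percentage points lower from compound 1 to compound 2 (beyond the scatter) follows a change to 4-chloro-2-fluorophenyl, and the step of a number 21 percentage points lower from compound 1 to compound 3 (beyond the scatter) follows a change to 3-methylbenzyl, each on the same amine nitrogen in a ring. Between compound 2 and compound 3 the step of a number 3 percentage points higher from compound 2 to compound 3 (within the scatter) stays within the scatter, so those two cannot be ordered.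

Compound 4, `CCCn1c(=O)[nH]c2nc(-c3ccc(S(=O)(=O)N4CCN(c5ccccc5C)CC4)cc3)[nH]c2c1=O`, has not yet been measured. It differs from compound 1 in one place: 2-methylphenyl in place of 4-fluorophenyl on an amine nitrogen in a ring. The change is of the same kind as the two measured steps away from compound 1, a different aromatic group on the ring nitrogen, and both of those steps were modest falls beyond the scatter. Neither measured step replaces the fluorine with a methyl on the ring itself, so the bearing is indirect. Compound 4 is therefore expected to sit below compound 1 by a modest amount, a number 14 percentage points lower from compound 1 to compound 4 (beyond the scatter). The estimate for compound 4 is 24%, expected between 8% and 42%.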

Compound 4, a percentage reported as inhibition, at one concentration (the size of the read-out at that concentration, not a potency): 25%
Beside the measured number, compound 4's estimate is 1 percentage points below it, within the range that was stated.
By their numbers in this assay, from the lowest: compounds 2, 3 and 4 (each within the scatter of the next, the first and the last beyond it); then compound 1.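

In this assay a third replacement on the amine nitrogen in a ring, 2-methylphenyl, also falls short of 4-fluorophenyl, with a number 13 percentage points lower from compound 1 to compound 4 (beyond the scatter), so all three replacements shown give a lower number, even though this one has the same count of heavy atoms and the same kind of carbon-only aromatic ring as the group it replaces. The replacements can also differ from one another, since a number 11 percentage points higher from compound 2 to compound 4 (beyond the scatter), while a number 8 percentage points higher from compound 3 to compound 4 (within the scatter) leaves those two compounds unordered. Nothing measured on these compounds explains why the number follows the group on this nitrogen.

Going by these compounds, whether the higher number of compound 1 goes with the fluorine itself or with where a group sits on the phenyl ring stays open, and a plain phenyl or a 4-methylphenyl on the same nitrogen would bear on that question. How a pyridine ring or a 4-methoxyphenyl group on this nitrogen would read in this assay also stays open, and a single tested concentration gives no potency for any of these compounds.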